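Swapping the benzyl substituent in a piperazine dithiocarbamate

The source may report more compounds than this note shows. Statements on the series, on what has been measured and on what is new or still open speak of the compounds shown alone.

Going by the values given here, compound 2 `COc1ccc(Cn2cc(CSC(=S)N3CCN(C(=O)OCc4ccccc4)CC3)nn2)cc1` gives the lower of the two numbers so far: in a functional assay on MCF7 cells (Homo sapiens) for inhibition, read by MTT assay, with a stated time of 72 h (a higher number here means a weaker inhibitor, a lower number a stronger inhibitor), compound 2 gives 30500 nM, while compound 1 `COc1ccc(-n2cc(CSC(=S)N3CCN(C(=O)OC(C)(C)C)CC3)nn2)cc1` gives 93100 nM, a gap beyond the scatter. Compound 3 `O=C(OCc1ccccc1)N1CCN(C(=S)SCc2cn(Cc3ccccc3F)nn2)CC1` differs from compound 2 by 2-fluorophenyl in place of 4-methoxyphenyl on a saturated chain carbon bound to an aromatic nitrogen, that is, 4-methoxybenzyl to 2-fluorobenzyl. Among the compounds with values here, no single-change step between measured compounds is available to guide this, so only a modest step, not clearly beyond the scatter, is expected from compound 2 to compound 3 a 1.0-fold higher number from compound 2 to compound 3 (0.02 log units; within the scatter). Compound 3 is therefore estimated at 32000 nM in this assay, within 10000 nM to 100000 nM.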

Compound 3, half-maximal inhibitory concentration: 7950 nM
The estimate for compound 3 lay 4.0-fold (0.60 log units) above the measured number, and the stated range ends above it.
By their numbers in this assay, from the lowest: compound 3; then compound 2; then compound 1.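

In this assay the change of 4-methoxyphenyl to 2-fluorophenyl on a saturated chain carbon bound to an aromatic nitrogen gives a 3.8-fold lower number from compound 2 to compound 3 (0.58 log units; beyond the scatter) and so shows that this position responds to the aryl group it carries. Compounds 1 and 2 differ in more than one place and could not show this. Nothing at hand explains the step.

From the compounds shown here alone, the change replaces the methoxy group and introduces fluorine at once, so the share of each stays open. Where an unsubstituted benzyl group or a pyridine ring would fall at this position also remains open.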